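Urea to amide: a trifluoromethylphenyl carbonyl in the shared core

The compounds below may be only part of what the source reports. "The series", "measured", "known", "first", "only" and "open" are said of these compounds alone.

Measured compounds in a functional assay on HCC 2998 cells (Homo sapiens) for inhibition, read by sulforhodamine B assay, with a stated time of 48 h, tested at 100 uM; on this read-out lower numbers stand for a stronger effect and higher numbers for a weaker effect at the one concentration tested:
compound 1 `O=C(Nc1cccc(-n2cc(-c3ccncc3)c(-c3cc(O)cc(Cl)c3)n2)c1)Nc1ccc(Cl)c(Cl)c1` gives -55%
compound 2 `COc1cc(Cl)cc(-c2nn(-c3cccc(NC(=O)Nc4ccc(Cl)c(C(F)(F)F)c4)c3)cc2-c2ccncc2)c1` gives -75%
compound 3 `COc1cc(Cl)cc(-c2nn(-c3cccc(NC(=O)Nc4ccc(Cl)c(Cl)c4)c3)cc2-c2ccncc2)c1` gives -7%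

Compound 3 stands highest of the three numbers on this assay. Its nearest neighbour is compound 1, and the step of a number 48 percentage points higher from compound 1 to compound 3 (beyond the scatter) comes from methyl in place of hydrogen on an oxygen on an aromatic ring. The furthest is compound 2, and the step of a number 68 percentage points higher from compound 2 to compound 3 (beyond the scatter) comes from chloro in place of trifluoromethyl on an aromatic carbon. Both steps are large and go in the same direction, so compound 3 is the weakest of the three on this read-out.

Compound 4 `COc1cc(Cl)cc(-c2nn(-c3cccc(NC(=O)c4cccc(C(F)(F)F)c4)c3)cc2-c2ccncc2)c1` differs from compound 3 as 3-(trifluoromethyl)phenyl in place of (3,4-dichlorophenyl)amino on a carbonyl carbon. Neither measured step covers this change: the difference from compound 2 to compound 3 touches a trifluoromethyl, but on another ring position and without removing an amide-type nitrogen. Among the compounds with values here, no step here bears directly on the loss of a hydrogen-bond donor from the urea. Given how strongly this series moved with single changes, the expected step for compound 4 is a number 23 percentage points lower from compound 3 to compound 4 (beyond the scatter), downward, with wide uncertainty. Compound 4 is therefore estimated at -30%, within the range -80% to 20%.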

Compound 4, a percentage reported as activity, at one concentration (the size of the read-out at that concentration, not a potency): 15%
The estimate for compound 4 lay 45 percentage points below the measured number, within the range that was stated.
By their numbers in this assay, from the lowest: compound 2; then compound 1; then compound 3; then compound 4.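

In this assay, putting 3-(trifluoromethyl)phenyl on the carbonyl carbon in place of (3,4-dichlorophenyl)amino gives a number 22 percentage points higher from compound 3 to compound 4 (beyond the scatter), while the same replacement of (4-chloro-3-(trifluoromethyl)phenyl)amino gives a number 90 percentage points higher from compound 2 to compound 4 (beyond the scatter). The earlier steps shown here kept the amide-type nitrogen on both sides of this carbonyl and changed only a substituent, whereas these two steps show that replacing the whole arylamino group moves the number upward from both ureas, modestly from one and largely from the other, so the effect of this change depends on which urea it starts from. Each step removes the amino nitrogen and its hydrogen-bond donor and alters the ring substituents at the same time, so the two contributions cannot be separated, and nothing in the data given accounts for either step.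

The compounds shown leave open how an amide would read if it carried the 3,4-dichlorophenyl or the 4-chloro-3-(trifluoromethyl)phenyl ring on its carbonyl, which would isolate the loss of the nitrogen from the change of ring. They also leave open whether a hydroxy in place of the methoxy would move the amide as it separates compound 1 from compound 3, and how a morpholine or a carboxylic acid on the carbonyl-bearing ring would read.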